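The source may report more compounds than this note shows. Statements on the series, on what has been measured and on what is new or still open speak of the compounds shown alone.

Three compounds have been measured so far:
compound 1, `CC(C)N(Cc1cccc(OCCCCCC(=O)O)c1)C(=O)c1ccc(-c2ccncc2)cc1`, with > 26000 nM;
compound 2, `CCOC(=O)CCCCCOc1cccc(CN(C(=O)c2ccccc2)C(C)C)c1`, with > 26000 nM;
compound 3, `CCOC(=O)CCCCCOc1cccc(CN(C(=O)c2ccc(-c3ccc4ccccc4c3)cc2)C(C)C)c1`, with > 26000 nM.

All three numbers come from an ADME assay on HepG2 cells (Homo sapiens) for cytotoxicity, read by CellTiter-Glo and resazurin assay, with a stated time of 72 h; a higher number here means that more compound is needed for the effect, a lower number that less compound is needed. For compound 3 the value > 26000 nM is a limit of the assay rather than a measured number. The same holds across the whole set, since every result sits at the limit of > 26000 nM in this assay, at which 3 of the 3 values shown sit. Compound 4, `CCOC(=O)CCCCCOc1cccc(CN(C(=O)c2ccc(-c3ccncc3)cc2)C(C)C)c1`, has not yet been measured. It differs from compound 3 in a single place: pyridin-4-yl in place of naphthalen-2-yl on an aromatic carbon. Within the data shown here, the only measured step that touches this part of the shared core is a step that the two limits leave unreadable from compound 2 to compound 3; it starts and ends at the limit and so gives no readable size. Compound 1, which also carries a pyridin-4-yl group, likewise gives only a limit, > 26000 nM. Nothing in the measured steps therefore points to a change beyond the scatter, and compound 4 is expected to stay at the limit as well, a step that the limit leaves unreadable from compound 3 to compound 4. The estimate for compound 4 is 40000 nM, with a range from 20000 nM to 200000 nM.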

Compound 4, half-maximal effective concentration: > 26000 nM
Compound 4 gave a limit, no number; the forecaster's own chance of this, stated with the estimate: 85%; the middle value is on the limit's open side.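

In compound 4 the result of > 26000 nM is a limit of the assay, so no step from compound 1, compound 2 or compound 3 to compound 4 can be read: the limit of > 26000 nM in this assay, at which 4 of the 4 values shown sit.

The compounds shown leave open whether any of these group changes alters the concentration needed in this assay.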